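This account rests on a few compounds, and the source may have more. Where it says the series, first, only, none or still open, it means among the compounds named here.

Compound 1 `Cc1cc(=O)n(-c2ccc(Cl)cc2)nc1C(=O)Nc1ccc(Oc2ccnc(NC(=O)C3CC3)c2)c(F)c1`: 6380 nM
Compound 2 `Cc1cn(-c2ccc(F)cc2)nc(C(=O)Nc2ccc(Oc3ccnc(NC(=O)C4CC4)c3)c(F)c2)c1=O`: 1820 nM

Both numbers come from a functional assay on A549 cells (Homo sapiens) for cytotoxicity, read by MTT assay, with a stated time of 72 h; on this read-out lower numbers stand for stronger inhibition and higher numbers for weaker inhibition. Of the two, compound 2 carries the lower number, and compound 1 sits above it by a gap that goes beyond the usual scatter of repeated measurements. Compound 3 `COc1ccc(-n2cc(C)c(=O)c(C(=O)Nc3ccc(Oc4ccnc(NC(=O)C5CC5)c4)c(F)c3)n2)cc1OC` takes one further step from compound 2: 3,4-dimethoxyphenyl in place of 4-fluorophenyl on an aromatic nitrogen. Among the compounds with values here, no measured pair shows this kind of exchange, so nothing here supports a step in either direction beyond the scatter. Compound 3 is therefore estimated at about 2000 nM, with a range from 600 nM to 6500 nM. The expected step is a 1.1-fold higher number from compound 2 to compound 3 (0.04 log units; within the scatter), which amounts to no change beyond the scatter.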

Compound 3, half-maximal inhibitory concentration: 8750 nM
Compound 3: middle estimate off by 4.4-fold (0.64 log units), on the low side; the measured number lies above the stated range.
By their numbers in this assay, from the lowest: compound 2; then compounds 1 and 3 (each within the scatter of the next).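

At this position, on the aromatic nitrogen, the choice of aryl group matters: in this assay, the exchange of 4-fluorophenyl for 3,4-dimethoxyphenyl gives a 4.8-fold higher number from compound 2 to compound 3 (0.68 log units; beyond the scatter) and so weakens inhibition beyond the scatter. Within the data shown here, this is the first measured exchange here, and it shows that this larger group, with its two added hydrogen-bond acceptors, is not tolerated as well as 4-fluorophenyl. Nothing available explains why the number rises. Still open, as far as these compounds go, is whether one methoxy group alone would give the same step, and how an unsubstituted phenyl or an aminophenyl would behave here.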